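Ring closure on the acid-bearing carbon of compound 3

The source may hold more compounds than are shown below. What is called first, only, known or untested is meant among the compounds shown, and "the series" means these compounds.

Three compounds of the series carry numbers in a functional assay on HFL1 cells for antagonist activity at sphingosine 1-phosphate receptor 2 (Homo sapiens), read by ELISA, with a stated time of 24 h, in the presence of a further agent that is not named here; on this read-out higher numbers stand for weaker inhibition and lower numbers for stronger inhibition. Compound 1 `O=C(O)Cn1nc(Cn2cc3cc(OCC4CC4)c(Cl)cc3n2)c2ccccc2c1=O` gives 647 nM, compound 2 `COC(C(=O)O)c1nn(Cc2cn3cc(OCC4CC4)c(Cl)cc3n2)c2ccccc2c1=O` gives 217 nM, and compound 3 `O=C(O)Cc1nn(Cc2cn3cc(OCC4CC4)c(Cl)cc3n2)c2ccccc2c1=O` gives 60 nM, the lowest of the three, with gaps to compound 2 and to compound 1 that both lie beyond the scatter. Among the compounds with values here, the only step that can be isolated is a 3.6-fold lower number from compound 2 to compound 3 (0.56 log units; beyond the scatter), the replacement of methoxy by hydrogen on the saturated chain carbon bound to an aromatic carbon and a carbonyl carbon.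

Compound 4 `O=C(O)C1(c2nn(Cc3cn4cc(OCC5CC5)c(Cl)cc4n3)c3ccccc3c2=O)CC1` is not yet measured. It differs from compound 3 by 1-carboxycyclopropyl in place of carboxymethyl on an aromatic carbon; the carbon that carried methoxy in compound 2 is now part of a three-membered ring. The step of a 3.6-fold lower number from compound 2 to compound 3 (0.56 log units; beyond the scatter) is the only one that bears on this, and it shows that a substituent on that carbon went with a modestly higher number in this assay . Within the data shown here, compound 1 places the acid chain elsewhere and offers no isolated step. A modest rise in the number, of roughly the size seen when methoxy was present, is therefore the expectation, though a result within the scatter cannot be ruled out. Compound 4 is estimated at 150 nM, with a range from 45 nM to 500 nM. This corresponds to an expected step of a 2.5-fold higher number from compound 3 to compound 4 (0.40 log units; beyond the scatter).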

Compound 4, half-maximal inhibitory concentration: 304 nM
Compound 4: the middle estimate sits 2.0-fold (0.31 log units) below what was measured; low and high end bracket the measured number.
By their numbers in this assay, from the lowest: compound 3; then compounds 2 and 4 (each within the scatter of the next); then compound 1.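

Ring closure on the acid-bearing carbon is not tolerated without cost: in this assay the change to 1-carboxycyclopropyl on this aromatic carbon gives a 5.1-fold higher number from compound 3 to compound 4 (0.70 log units; beyond the scatter), which extends the earlier methoxy observation from a single substituent to a three-membered ring of carbon only. Among the acid-bearing groups at this position, the unbranched carboxymethyl of compound 3 now has the lowest number, and the two groups substituted on that carbon cannot be told apart, with a 1.4-fold higher number from compound 2 to compound 4 (0.15 log units; within the scatter). The three compounds thus show that a methoxy and a cyclopropane closure at this carbon read alike, while nothing measured here accounts for the rise seen with either group.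

Still open, as far as these compounds go, is whether a single methyl on the acid-bearing carbon, or a larger closure such as 1-carboxycyclobutyl, would fall with compound 3 or with compounds 2 and 4. Also open, from the compounds shown here alone, is how the position responds when the carboxylic acid itself gives way to a primary amide or a tetrazole on the same carbon.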